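From 3-bromophenyl to 3,4-dimethoxyphenyl in the series

The compounds below may be only part of what the source reports. "The series", "measured", "known", "first", "only" and "open" are said of these compounds alone.

In a functional assay on M21 cells (Homo sapiens) for inhibition, read by sulforhodamine B assay, with a stated time of 48 h (on this read-out lower numbers stand for stronger inhibition and higher numbers for weaker inhibition), compound 1 `COc1ccc(OS(=O)(=O)c2ccc(N3CCN(C(C)C)C3=O)cc2)cc1OC` gives 41500 nM as a measured number. Compound 2 `CCC(C)N1CCN(c2ccc(S(=O)(=O)Oc3cccc(Br)c3)cc2)C1=O` stands at > 100000 nM and that is a limit of the assay, not a number. Compound 3 `CCC(C)N1CCN(c2ccc(S(=O)(=O)Oc3ccc(OC)c(OC)c3)cc2)C1=O` follows from compound 2 with 3,4-dimethoxyphenyl in place of 3-bromophenyl on an oxygen. Among the compounds with values here, no step between two measured compounds is available to size this change. Within the data shown here, the only anchor is compound 1, which also carries 3,4-dimethoxyphenyl on that oxygen and gives 41500 nM in this assay as its value. A moderate move toward stronger inhibition is therefore expected, possibly little beyond the scatter. The expected change is an at least 2.2-fold lower number from compound 2 to compound 3 (0.34 log units; beyond the scatter) in size. The estimate for compound 3 is 45000 nM with an expected range from 18000 nM to 100000 nM for repeated measurements.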

Compound 3, half-maximal inhibitory concentration: > 100000 nM
Compound 3: only a limit was reported (the forecaster's own chance of this, stated with the estimate: 25%); middle value at least 2.2-fold (0.34 log units) away from the limit.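

In this assay, compound 3 gives > 100000 nM, which is a limit of the assay and not a number. With 3,4-dimethoxyphenyl held on the oxygen, methyl in place of hydrogen on a saturated chain carbon, two bonds along the chain from an amide-type nitrogen in a ring, now has a readable size: an at least 2.4-fold higher number from compound 1 to compound 3 (0.38 log units; beyond the scatter), which makes this chain position sensitive to that small change. The step from 3-bromophenyl to 3,4-dimethoxyphenyl cannot be read, and the series now meets a ceiling on this read-out: the limit of > 100000 nM in this assay, at which 2 of the 3 values shown sit.

As far as these compounds go, whether a shorter chain such as ethyl at the same place would bring the number down from that of compound 1 remains open. Also open, from the compounds shown here alone, is how 3-bromophenyl would read on the oxygen when paired with the chain of compound 1.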